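Swapping vinyl for but-1-en-1-yl on compound 3

This account rests on a few compounds, and the source may have more. Where it says the series, first, only, none or still open, it means among the compounds named here.

Compound 1 `CC/C=C/C(=O)Nc1cccc(Oc2nc(Nc3cccc(OC)c3)nc3c2CSCC3)c1` gives > 50000 nM as a limit
Compound 2 `CC/C=C/C(=O)Nc1cccc(Oc2nc(Nc3cccc(C#N)c3)nc3c2CSCC3)c1` gives > 50000 nM as a limit
Compound 3 `C=CC(=O)Nc1cccc(Oc2nc(Nc3ccc(OC)nc3)nc3c2CSCC3)c1` gives > 50000 nM as a limit

These readings come from an ADME assay on L02 cells (Homo sapiens) for cytotoxicity, read by MTT assay, with a stated time of 72 h (a lower number here means a stronger inhibitor, a higher number a weaker inhibitor), and all three are limits, not numbers. The record so far is the limit of > 50000 nM in this assay, at which 3 of the 3 values shown sit, and so offers no graded scale. In this assay compound 3 gives > 50000 nM as a limit, which is all that is known of where it stands.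

Compound 4 `CC/C=C/C(=O)Nc1cccc(Oc2nc(Nc3ccc(OC)nc3)nc3c2CSCC3)c1` differs from compound 3 in one place, with but-1-en-1-yl in place of vinyl on a carbonyl carbon is the whole change.

Going by the values given here, the only measured step is a step that the two limits leave unreadable from compound 1 to compound 2 and it concerns cyano in place of methoxy, so it gives no size to carry over. Compound 1 already carries but-1-en-1-yl, and its > 50000 nM is a limit. Compound 2 carries it too, and its > 50000 nM is also a limit.

No step beyond the scatter is therefore expected, in either direction. The estimated step is a number no higher from compound 3 to compound 4 (the limit leaves the size open) in this assay terms. For compound 4 the estimated value is 50000 nM with an expected range from 25000 nM to 100000 nM and a report as a limit is the likeliest outcome.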

Compound 4, half-maximal inhibitory concentration: > 50000 nM
Compound 4 gave a limit, no number (the forecaster's own chance of this, stated with the estimate: 85%); the middle value lies on the limit itself.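

No step can be read from compound 1, compound 2 or compound 3 to compound 4, because all four compounds end at the same limit: the limit of > 50000 nM in this assay, at which 4 of the 4 values shown sit.

The compounds shown leave open how far past that limit each one lies, and whether but-1-en-1-yl in place of vinyl changes anything in this assay.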